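This account rests on a few compounds, and the source may have more. Where it says the series, first, only, none or still open, it means among the compounds named here.

Compound 1 `COc1c(N2CCN(CCC#N)C(C)C2)c(F)cc2c(=O)c(C(=O)O)cn(C3CC3)c12`: 500 ug/mL
Compound 2 `COC(=O)CN1CCN(c2c(F)cc3c(=O)c(C(=O)O)cn(C4CC4)c3c2OC)CC1C`: 500 ug/mL
Compound 3 `COc1c(N2CCN(C/C(C)=N/NC(C)=O)C(C)C2)c(F)cc2c(=O)c(C(=O)O)cn(C3CC3)c12`: 707 ug/mL

In an ADME assay on Vero cells (Chlorocebus sabaeus) for cytotoxicity, read by MTT assay, with a stated time of 72 h (a lower number here means that less compound is tolerated, a higher number that more compound is tolerated), compound 1 stands level with compound 2, the two together the lowest of the three numbers, and within the scatter of compound 3. The steps among them are all small: no change at the digits printed from compound 1 to compound 2 (within the scatter), a 1.4-fold higher number from compound 1 to compound 3 (0.15 log units; within the scatter), a 1.4-fold higher number from compound 2 to compound 3 (0.15 log units; within the scatter). Compound 4 `CO/N=C(\C)CCN1CCN(c2c(F)cc3c(=O)c(C(=O)O)cn(C4CC4)c3c2OC)CC1C` is not yet measured. It differs from compound 1 by a group of 5 heavy atoms (3 carbon, 1 nitrogen, 1 oxygen; no ring) in place of a group of 2 heavy atoms (1 carbon, 1 nitrogen; no ring), on a saturated chain carbon, two bonds along the chain from an amine nitrogen in a ring. All three measured steps change a group at the same saturated chain carbon and none moves the number beyond the scatter, so the step to compound 4 in this assay is expected to be of the same kind: no change at the digits printed from compound 1 to compound 4 (within the scatter). Compound 4 is therefore estimated at 500 ug/mL, with a range from 350 ug/mL to 720 ug/mL.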

Compound 4, half-maximal cytotoxic concentration: 157 ug/mL
The estimate for compound 4 lay 3.2-fold (0.50 log units) above the measured number; the measured number lies below the stated range.
By their numbers in this assay, from the lowest: compound 4; then compounds 1, 2 and 3 (each within the scatter of the next).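

In this assay, within the data shown here, the groups on this saturated chain had so far left the number unmoved, and compound 4 shows that a change here can lower it beyond the scatter. The group of 5 heavy atoms entering in place of cyano gives a 3.2-fold lower number from compound 1 to compound 4 (0.50 log units; beyond the scatter) and the comparisons with the other two compounds give a 3.2-fold lower number from compound 2 to compound 4 (0.50 log units; beyond the scatter) and a 4.5-fold lower number from compound 3 to compound 4 (0.65 log units; beyond the scatter). Nothing shown explains this fall. On these data alone, whether a ketone or a primary amine on the same chain would lower the number as well remains open.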